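Shifting the thiazole attachment of compound 3

This account rests on a few compounds, and the source may have more. Where it says the series, first, only, none or still open, it means among the compounds named here.

Measured in a functional assay on MCF7 cells (Homo sapiens) for antiproliferative activity, read by CellTiter-Glo, with a stated time of 5 days; a higher number here means a weaker inhibitor, a lower number a stronger inhibitor:
compound 1 `CC/C(=C(/c1ccc(/C=C/C(=O)O)cc1)c1ccn2nncc2c1)c1ccccc1`: > 500 nM
compound 2 `CC/C(=C(/c1ccc(/C=C/C(=O)O)cc1)c1ccc2ncsc2c1)c1ccccc1`: > 500 nM
compound 3 `CC/C(=C(/c1ccc(/C=C/C(=O)O)cc1)c1ccc(-c2cscn2)cc1)c1ccccc1`: 120 nM

Compound 3 is the only one of the three read as a number, at 120 nM. Compound 1 gives > 500 nM, which is a limit and not a number. Compound 2 gives > 500 nM, which is likewise a limit. The series thus has one shared boundary: the limit of > 500 nM in this assay, at which 2 of the 3 values shown sit.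

Compound 4 `CC/C(=C(/c1ccc(/C=C/C(=O)O)cc1)c1ccc(-c2nccs2)cc1)c1ccccc1` differs from compound 3 in one place only: 1,3-thiazol-2-yl in place of 1,3-thiazol-4-yl on an aromatic carbon. The new group, 1,3-thiazol-2-yl, stands in place of 1,3-thiazol-4-yl on an aromatic carbon of a six-membered aromatic ring of carbon only, para to a large group.

Within the data shown here, the one measured step is a step that the two limits leave unreadable from compound 1 to compound 2. Among the measured compounds shown here, it offers no size to carry over, and no measured step exchanges one of these two groups for the other. The expectation in this assay therefore rests on compound 3 at 120 nM, with no definite direction and no change expected beyond the scatter. The expected move is a 1.3-fold higher number from compound 3 to compound 4 (0.10 log units; within the scatter). For compound 4 the estimate is 150 nM, with an expected range from 50 nM to 450 nM.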

Compound 4, half-maximal inhibitory concentration: 290 nM
For compound 4 the middle estimate is 1.9-fold (0.29 log units) below the measured one, within the range that was stated.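

In this assay, the point through which the thiazole is attached matters at this place on the six-membered aromatic ring: 1,3-thiazol-2-yl in place of 1,3-thiazol-4-yl keeps the same atoms, joined differently, and gives a 2.4-fold higher number from compound 3 to compound 4 (0.38 log units; beyond the scatter). Among these compounds, this is the first step with a readable size, and it is a modest one; the earlier step between the two fused groups of compound 1 and compound 2 cannot be read. With a number for compound 4, both thiazole isomers are now read as numbers, clear of the one boundary in the series: the limit of > 500 nM in this assay, at which 2 of the 4 values shown sit.

The compounds shown do not tell how the 1,3-thiazol-5-yl isomer, an oxazolyl group or a pyridyl group would read at this same place. Nor do they tell whether the step between the two thiazoles would keep its size with an ester or an amide in place of the carboxylic acid on the shared core.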